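Series notes: amino group at the chain end

The source may hold more compounds than are shown below. What is called first, only, known or untested is meant among the compounds shown, and "the series" means these compounds.

Going by the values given here, compound 2 `O=c1cc(-c2ccccc2)oc2ccc(OCCCCCCN3CCNC(CCO)C3)cc12` stands at 94 nM in an assay on isolated protein (Cavia porcellus) with Sigma non-opioid intracellular receptor 1 (Homo sapiens) as the target, read by radioligand binding (a lower number here means a stronger inhibitor, a higher number a weaker inhibitor), the higher of the two numbers measured so far; the other belongs to compound 1 `O=c1cc(-c2ccccc2)oc2ccc(OCCCCCCN3CCCCC3)cc12` at 54 nM, and the two lie within the scatter of each other. Among the compounds with values here, the single measured step, a 1.7-fold higher number from compound 1 to compound 2 (0.24 log units; within the scatter), shows that exchanging one non-aromatic cyclic amine for another at this position gives a number within the scatter.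

Compound 3 `NCCCCCCOc1ccc2oc(-c3ccccc3)cc(=O)c2c1` goes further along the same line: amino in place of 3-(2-hydroxyethyl)piperazin-1-yl on a saturated chain carbon, six bonds along the chain from an oxygen on an aromatic ring. Within the data shown here, no measured step covers the loss of the ring itself; the step from compound 1 to compound 2 bears on it only in that both terminal groups measured so far were cyclic and gave similar numbers. With only the amino group remaining, compound 3 is expected to be a weaker inhibitor than either measured compound, and the expected step is a 3.2-fold higher number from compound 2 to compound 3 (0.50 log units; beyond the scatter), beyond the scatter. Among the measured compounds shown here, compound 3 is therefore estimated at 300 nM, with a range from 80 nM to 1200 nM, wide since no measured compound lacks the ring.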

Compound 3, half-maximal inhibitory concentration: 3700 nM
Beside the measured number, compound 3's estimate is 12-fold (1.09 log units) below it; measured number outside the range, above it.
By their numbers in this assay, from the lowest: compounds 1 and 2 (each within the scatter of the next); then compound 3.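

In this assay this chain end proves far less forgiving than the exchange of one cyclic amine for another suggested: removing the ring to leave only amino gives a 39-fold higher number from compound 2 to compound 3 (1.60 log units; beyond the scatter) and a 69-fold higher number from compound 1 to compound 3 (1.84 log units; beyond the scatter), both large and beyond the scatter, while piperidin-1-yl and 3-(2-hydroxyethyl)piperazin-1-yl stay within the scatter of each other. Among these three compounds, then, the size of the change at this saturated chain carbon is set by the loss of the whole cyclic amine, though the change to amino removes the ring and all the carbon atoms of the group together, so the two cannot be told apart here. No available evidence accounts for the large loss.

The compounds shown leave open whether an open-chain amine such as dimethylamino or diethylamino would stay near the two cyclic amines or fall toward the primary amine of compound 3. They also leave open whether a shorter or longer chain would change the gap between piperidin-1-yl and amino at the chain end.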